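The source may report more compounds than this note shows. Statements on the series, on what has been measured and on what is new or still open speak of the compounds shown alone.

Of the compounds shown here, two sharing one core have been tested in a functional assay on UACC-62 cells (Homo sapiens) for inhibition, read by sulforhodamine B assay, with a stated time of 48 h; on this read-out higher numbers stand for weaker inhibition of growth and lower numbers for stronger inhibition of growth. Compound 1 `O=C(Nc1cccc(-n2cc(-c3ccncc3)c(-c3ccc(Cl)c(O)c3)n2)c1)Nc1cccc(C(F)(F)F)c1` gives 6910 nM in this assay. Compound 2 `COc1cc(-c2nn(-c3cccc(NC(=O)c4cccc(C(F)(F)F)c4)c3)cc2-c2ccncc2)ccc1Cl` reaches only the limit of > 50000 nM in this assay, so for it no number is known. That place is marked by the limit of > 50000 nM in this assay, at which 1 of the 2 values shown sits, where one of the two values shown sits.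

Compound 3 `COc1cc(-c2nn(-c3cccc(NC(=O)Nc4cccc(C(F)(F)F)c4)c3)cc2-c2ccncc2)ccc1Cl` has not yet been measured in this assay. It differs from compound 2 by (3-(trifluoromethyl)phenyl)amino in place of 3-(trifluoromethyl)phenyl on a carbonyl carbon. The same (3-(trifluoromethyl)phenyl)amino group on the carbonyl carbon is present in compound 1, which gives a measurable number. Among the measured compounds shown here, no step between measured compounds describes this change directly, so the expectation rests on that resemblance alone. The step from compound 2 to compound 3 is expected to be an at least 2.5-fold lower number from compound 2 to compound 3 (0.39 log units; beyond the scatter), towards stronger inhibition and beyond the usual scatter. Compound 3 is therefore estimated at 20000 nM, with a range from 5000 nM to 60000 nM.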

Compound 3, concentration for total growth inhibition: 1590 nM
Estimate against measurement, compound 3: 13-fold (1.10 log units) above; measured number below the stated range.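

In this assay, (3-(trifluoromethyl)phenyl)amino in place of 3-(trifluoromethyl)phenyl on the carbonyl carbon gives an at least 31-fold lower number from compound 2 to compound 3 (1.49 log units; beyond the scatter), so this single change at this position separates a compound with a measurable number from one without. On these data alone, compound 2 has only a limit and not a number, so the full size of this step stays unknown: the limit of > 50000 nM in this assay, at which 1 of the 3 values shown sits. With the (3-(trifluoromethyl)phenyl)amino group kept in place, methyl in place of hydrogen on the oxygen on the aromatic ring gives a 4.3-fold lower number from compound 1 to compound 3 (0.64 log units; beyond the scatter), towards stronger inhibition and modest in size.

The compounds shown cannot tell whether the hydrogen on the entering nitrogen matters, since none carries a methyl on that nitrogen or a methylene in its place. As far as these compounds go, how an ethyl on the oxygen would compare with the methyl also stays open.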